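Pyrazole Urea Series: Cyano Substitution on the Piperazine Core

A few compounds are considered here, and "the series" means these few. Any claim that something is new, unique, unknown or untested is made for them only; others in the source may bear on it.

Compound 1 `O=C(NCc1ccc(OCc2ccccc2)cc1)n1cccn1` gives 800 nM in an assay on membranes from brain for binding affinity to Fatty-acid amide hydrolase 1 (Mus musculus), read by fluorescence, with stated times of 1 h and 30 min; on this read-out lower numbers stand for stronger inhibition and higher numbers for weaker inhibition. Compound 2 `Cc1cnn(C(=O)N2CCN(C(c3ccc(OCc4ccccc4)cc3)c3ccc(OCc4ccccc4)cc3)CC2)c1` gives only a limit in this assay, > 100000 nM. Compound 3 `O=C(N1CCN(C(c2ccc(OCc3ccccc3)cc2)c2ccc(OCc3ccccc3)cc2)CC1)n1cccn1` likewise gives only a limit, > 100000 nM. Both sit at the limit of > 100000 nM in this assay, at which 2 of the 3 values shown sit. The step that the two limits leave unreadable from compound 2 to compound 3, hydrogen in place of methyl on an aromatic carbon, therefore cannot be read. Compound 3 thus stands at the limit of this assay, with no number attached to it.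

Compound 4 `N#Cc1cnn(C(=O)N2CCN(C(c3ccc(OCc4ccccc4)cc3)c3ccc(OCc4ccccc4)cc3)CC2)c1` differs from compound 3 by cyano in place of hydrogen on an aromatic carbon; cut one bond further out, the change reads 1H-pyrazol-1-yl to 4-cyano-1H-pyrazol-1-yl. Going by the values given here, no measured step of this kind exists, and the one step on the shared core, a step that the two limits leave unreadable from compound 2 to compound 3, is itself unreadable. Since compound 2 and compound 3 both sit at the limit of > 100000 nM in this assay, at which 2 of the 3 values shown sit, whatever group stands on that five-membered ring, compound 4 is expected to remain at or near the limit, a step of a number no higher from compound 3 to compound 4 (the limit leaves the size open). The estimate for compound 4 is 100000 nM, with a range from 10000 nM to 300000 nM.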

Compound 4, half-maximal inhibitory concentration: 790000 nM
Compound 4: the middle estimate sits 7.9-fold (0.90 log units) below what was measured, and the stated range ends below it.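

Going by these compounds alone, no step to compound 4 from compound 2 or compound 3 can be read, because both of those compounds give only a limit: the limit of > 100000 nM in this assay, at which 2 of the 4 values shown sit.

The compounds shown leave open how far hydrogen, methyl or cyano on the five-membered aromatic ring changes inhibition on this shared core.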